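A few compounds are considered here, and "the series" means these few. Any claim that something is new, unique, unknown or untested is made for them only; others in the source may bear on it.

Compound 1, `N#Cc1c(Nc2ccccc2)nc(SCc2nc3ccccc3[nH]2)nc1-c1ccccc1`: 2.4 nM
Compound 2, `N#Cc1c(-c2ccccc2)nc(SCc2nc3ccccc3[nH]2)nc1N1CCNCC1`: 2.5 nM

Of the compounds shown here, two have been measured in a functional assay on G-361 cells (Homo sapiens) for cytotoxicity, read by MTT assay, with a stated time of 3 days; on this read-out lower numbers stand for stronger inhibition and higher numbers for weaker inhibition. Compound 1 `N#Cc1c(Nc2ccccc2)nc(SCc2nc3ccccc3[nH]2)nc1-c1ccccc1` gives 2.4 nM, and compound 2 `N#Cc1c(-c2ccccc2)nc(SCc2nc3ccccc3[nH]2)nc1N1CCNCC1` gives 2.5 nM. Within the data shown here, the one step between them, a 1.0-fold higher number from compound 1 to compound 2 (0.02 log units; within the scatter), replaced one substituent on the shared core with another and left the number where it was. Among the measured compounds shown here, on the numbers so far, compound 2 is nearest to compound 1, and the two are within the scatter of each other.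

Compound 3 `CN1CCN(c2nc(SCc3nc4ccccc4[nH]3)nc(-c3ccccc3)c2C#N)CC1` has not yet been measured. It differs from compound 2 in one place: methyl in place of hydrogen on an amine nitrogen in a ring. For the measured compounds named here, no measured step bears directly on this change, which sits on the ring nitrogen of the group that entered in the step from compound 1 to compound 2; the only step available, a 1.0-fold higher number from compound 1 to compound 2 (0.02 log units; within the scatter), concerns a different position. Because a 1.0-fold higher number from compound 1 to compound 2 (0.02 log units; within the scatter) left the number unmoved, compound 3 is expected to stay close to compound 2 in this assay, with a step of a 1.1-fold higher number from compound 2 to compound 3 (0.05 log units; within the scatter) and no movement beyond the scatter. The estimate for compound 3 is 2.8 nM, within 1.2 nM to 7 nM.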

Compound 3, half-maximal inhibitory concentration: 14.7 nM
The estimate for compound 3 lay 5.3-fold (0.72 log units) below the measured number; measured number outside the range, above it.
By their numbers in this assay, from the lowest: compounds 1 and 2 (each within the scatter of the next); then compound 3.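

In this assay, the amine nitrogen of the piperazin-1-yl ring turned out to be a place where a small change registers: methyl in place of hydrogen there gave a 5.9-fold higher number from compound 2 to compound 3 (0.77 log units; beyond the scatter) even though the earlier exchange had given only a 1.0-fold higher number from compound 1 to compound 2 (0.02 log units; within the scatter) and so had shown no sensitivity to the group at this point of the shared core. The tolerance seen for piperazin-1-yl in place of anilino therefore does not carry over to 4-methylpiperazin-1-yl, which gives a 6.1-fold higher number from compound 1 to compound 3 (0.79 log units; beyond the scatter) and is a modest step beyond the scatter, from the addition of a single carbon on the ring nitrogen three ring bonds from the ring atom that bears the large group. Nothing measured in this account explains why the number moves with this one methyl.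

The compounds shown leave open whether the higher number belongs to methyl alone or would grow further with a longer chain such as ethyl or propyl on the same amine nitrogen. They also leave open how an acetyl group on that nitrogen would read, and how a morpholine ring in place of the piperazine would compare.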